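This account rests on a few compounds, and the source may have more. Where it says the series, first, only, none or still open, it means among the compounds named here.

Within the data shown here, in an ADME assay on microsomes from liver (Mus musculus, strain CD1) for metabolic stability, read by HPLC, using NADPH, with a stated time of 30 min (a higher number here means faster removal of the compound, a lower number slower removal), compound 2 `COc1cccc(NC(=O)c2nnn(Cc3ccc(SC)cc3)c2N)c1` stands highest of the two measured so far at 6.4 mL.min-1.g-1, while compound 1 `COc1cccc(NC(=O)c2nnn(CC3CCN(C(C)=O)CC3)c2N)c1` gives 0.7 mL.min-1.g-1. Compound 3 `COc1cccc(NC(=O)c2nnn(Cc3ccc(C4CC4)cc3)c2N)c1` differs from compound 2 by cyclopropyl in place of methylsulfanyl on an aromatic carbon. Among the measured compounds shown here, the only measured step, a 9.1-fold higher number from compound 1 to compound 2 (0.96 log units; beyond the scatter), exchanges the whole 1-acetylpiperidin-4-yl for 4-(methylsulfanyl)phenyl, so it bears only loosely on this smaller change. For the measured compounds named here, no measured step alters the methylsulfanyl alone. The expected result is a 1.3-fold lower number from compound 2 to compound 3 (0.11 log units; within the scatter), with no change beyond the scatter in this assay. The estimate for compound 3 is 5 mL.min-1.g-1, with an expected range of 2 mL.min-1.g-1 to 12 mL.min-1.g-1.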

Compound 3, intrinsic clearance in microsomes: 4.9 mL.min-1.g-1
Beside the measured number, compound 3's estimate is 1.0-fold (0.01 log units) above it; measured number inside the range.
By their numbers in this assay, from the lowest: compound 1; then compounds 3 and 2 (each within the scatter of the next).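

In this assay, cyclopropyl in place of methylsulfanyl on an aromatic carbon gives a 1.3-fold lower number from compound 2 to compound 3 (0.12 log units; within the scatter), so at this position an all-carbon ring can stand for the sulfur-bearing group with no change beyond the scatter. With a 7.0-fold higher number from compound 1 to compound 3 (0.85 log units; beyond the scatter) still separating the two, the gap from compound 1 first seen with compound 2 does not depend on the methylsulfanyl alone. No supporting data explain either step. Open, from the compounds shown here alone, is whether an amine or a carboxylic acid on the same aromatic carbon would shift intrinsic clearance beyond the scatter.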